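This account rests on a few compounds, and the source may have more. Where it says the series, first, only, none or still open, it means among the compounds named here.

Measured so far:
Compound 1, `COc1cccc(S(=O)(=O)/C=C/c2ccccn2)c1`: 100%
Compound 2, `COc1cccc(S(=O)(=O)/C=C/c2cccc(Cl)n2)c1`: 100%
Compound 3, `COc1ccc(S(=O)(=O)/C=C/c2cccnc2)cc1`: 99.5%

These three compounds were tested in an ADME assay on BV-2 cells (Mus musculus) for cytotoxicity, with a stated time of 24 h, tested at 10 uM; a lower number here means a stronger effect, a higher number a weaker effect of the compound at the concentration tested. Compound 1 gives 100%, and compound 2 gives 100%. The step of no change at the digits printed from compound 1 to compound 2 (within the scatter) belongs to a single structural change: chloro in place of hydrogen on an aromatic carbon. Compound 3 gives 99.5%; its value and those of compound 1 and compound 2 all fall within the usual scatter of one another, so no difference among the three can be claimed. Compound 3 and compound 1 are built from the same atoms joined differently; how their two cores differ is not broken down here.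

The unmeasured compound 4, `COc1ccc(S(=O)(=O)/C=C/c2cccnc2Cl)cc1`, is related to compound 3 by chloro in place of hydrogen on an aromatic carbon. Among the compounds with values here, this is the same kind of change as the one from compound 1 to compound 2, but not the same: in compound 2 the chloro sits meta to a large group, whereas in compound 4 it sits ortho to a large group. The earlier step of no change at the digits printed from compound 1 to compound 2 (within the scatter) left the read-out unchanged. Within the data shown here, a step of similar size, a number 0.5 percentage points lower from compound 3 to compound 4 (within the scatter), is expected here, resting on that earlier step, with the caution that the surroundings of the place differ and that only one prior example exists. Compound 4 is therefore estimated at 99%, expected to lie between 90% and 100%.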

Compound 4, a percentage reported as activity, at one concentration (the size of the read-out at that concentration, not a potency): 100%
The estimate for compound 4 lay 1 percentage points below the measured number; the measured number falls inside the stated range.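

In this assay, chloro in place of hydrogen on an aromatic carbon gives a number 0.5 percentage points higher from compound 3 to compound 4 (within the scatter), so the change behaves alike on the two cores that carry it: the same change on two cores in this assay, no change at the digits printed (within the scatter) from compound 1 to compound 2 and a number 0.5 percentage points higher (within the scatter) from compound 3 to compound 4, 0.5 percentage points apart, within the scatter of two such steps. In compound 4 the chloro stands next to the ring nitrogen and ortho to a large group, and even there the read-out shows no shift that can be told from ordinary scatter, so the flat result seen with the core of compound 1 carries over to the core of compound 3. Within the data shown here, this does not make it a general rule, since two pairs cover only two cores, one assay and one concentration, and a result this flat says nothing about what the same change would do in any other measurement.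

The compounds shown leave open whether a different group in the same place, such as a fluoro, a nitrile, an amine or a carboxylic acid, would leave the read-out just as flat as chloro does. They also leave open whether chloro would stay without effect on a core with a different group in place of the methoxy.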